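Methoxy Added to the Phenyl Group of Compound 2

This account rests on a few compounds, and the source may have more. Where it says the series, first, only, none or still open, it means among the compounds named here.

Compound 1, `Brc1cn2ccnc2c(-c2ccc3ncn(C4CCCCC4)c3c2)n1`, in a functional assay on NCI-H23 cells (Homo sapiens) for inhibition, read by sulforhodamine B assay, with a stated time of 48 h, tested at 10 uM; a lower number here means less inhibition, a higher number more inhibition at the concentration tested (going by the name of the read-out): 10.2%
Compound 2, `c1ccc(-c2cn3ccnc3c(-c3ccc4ncn(C5CCCCC5)c4c3)n2)cc1`, in this assay: 45.3%

Within the data shown here, compound 2 stands highest of the two numbers measured so far in this assay. Among the measured compounds shown here, the only measured step between the two, a number 35.1 percentage points higher from compound 1 to compound 2 (beyond the scatter), is large and beyond the scatter, and it concerns the replacement of bromo by phenyl on the shared core.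

Compound 3, `COc1ccc(-c2cn3ccnc3c(-c3ccc4ncn(C5CCCCC5)c4c3)n2)cc1`, is not yet measured. It differs from compound 2 by methoxy in place of hydrogen on an aromatic carbon. For the measured compounds named here, no measured step bears on this change: the step of a number 35.1 percentage points higher from compound 1 to compound 2 (beyond the scatter) tells what the phenyl itself brings, not what a substituent on that phenyl does. With nothing to point either way, the step from compound 2 to compound 3 in this assay is expected to be a number 2.7 percentage points higher from compound 2 to compound 3 (within the scatter), not beyond the scatter. Compound 3 is therefore estimated to give 48%, within a range of 25% to 70%.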

Compound 3, a percentage reported as inhibition, at one concentration (the size of the read-out at that concentration, not a potency): 62.2%
Beside the measured number, compound 3's estimate is 14.2 percentage points below it; measured number inside the range.
By their numbers in this assay, from the lowest: compound 1; then compound 2; then compound 3.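

The phenyl ring of compound 2 is therefore not an end point: in this assay, a substituent on it still moves the read-out, with methoxy para to a large group giving a number 16.9 percentage points higher from compound 2 to compound 3 (beyond the scatter). The gain from replacing bromo thus does not rest on the bare phenyl alone, and the change to 4-methoxyphenyl gives a number 52 percentage points higher from compound 1 to compound 3 (beyond the scatter), the widest gap among the compounds shown. No supporting measurement is available to explain why this substitution raises the inhibition.

The compounds shown leave open whether the rise is particular to methoxy or would also follow from another group at this place, such as hydroxy, an amine or a carboxylic acid. They also leave open whether a longer chain, such as ethoxy, would go further, and how methoxy would read elsewhere on the phenyl ring.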